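A second chloro on the phenyl ring of compound 2

This account rests on a few compounds, and the source may have more. Where it says the series, first, only, none or still open, it means among the compounds named here.

In an assay on HEK293 cells for activation of Kir3.1/Kir3.2 (Homo sapiens), read by thallium flux (a higher number here means that more compound is needed for the effect, a lower number that less compound is needed), compound 1 `Cc1cc(NC(=O)Cn2nnc(-c3ccccn3)n2)n(C2CCCCC2)n1` gives 14600 nM, and compound 2 `Cc1cc(NC(=O)Cn2nnc(-c3cccc(Cl)c3)n2)n(C2CCCCC2)n1` gives 300 nM, the lowest of the two numbers. Among the compounds with values here, the only step measured so far is a 49-fold lower number from compound 1 to compound 2 (1.69 log units; beyond the scatter). Compound 3 `Cc1cc(NC(=O)Cn2nnc(-c3cc(Cl)cc(Cl)c3)n2)n(C2CCCCC2)n1` differs from compound 2 by chloro in place of hydrogen on an aromatic carbon. Within the data shown here, no measured step adds a second chloro to this ring, so the expectation rests on compound 2 alone and on the observation that the first chloro-bearing phenyl, in the step from compound 1 to compound 2, sat well in this assay. The added chloro is one heavy atom with no donors or acceptors, and the likeliest outcome is a step from compound 2 to compound 3 that is expected to stay within the scatter, a 1.2-fold lower number from compound 2 to compound 3 (0.08 log units; within the scatter). Compound 3 is therefore estimated at 250 nM, with a range from 60 nM to 1200 nM.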

Compound 3, half-maximal effective concentration: 980 nM
Compound 3: the middle estimate sits 3.9-fold (0.59 log units) below what was measured; low and high end bracket the measured number.
By their numbers in this assay, from the lowest: compound 2; then compound 3; then compound 1.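

In this assay there is a 3.3-fold higher number from compound 2 to compound 3 (0.51 log units; beyond the scatter) when the second chloro enters, so at this position a further chloro on the 3-chlorophenyl ring does not lower the number and instead gives back part of what the first ring change gained. The 3,5-dichlorophenyl ring still stands well clear of the pyridin-2-yl ring, with a 15-fold lower number from compound 1 to compound 3 (1.17 log units; beyond the scatter) as the printed step, so the two chloro groups together remain far better than the pyridine in this series. Nothing available explains why the added chloro raises the number.

As far as these compounds go, it remains open whether a fluoro, a methyl or a methoxy in place of that hydrogen would raise the number as chloro does. From the compounds shown here alone, it is also open whether a nitrile or a trifluoromethyl could take the place of the first chloro on the phenyl ring.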